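This account rests on a few compounds, and the source may have more. Where it says the series, first, only, none or still open, it means among the compounds named here.

Measured in a functional assay on QG-56 cells (Homo sapiens) for antiproliferative activity; a lower number here means a stronger inhibitor, a higher number a weaker inhibitor:
- compound 1 `Cn1cncc1[C@@](N)(c1ccc(C#N)cc1)c1cc2cc([N+](=O)[O-])cc(-c3ccccc3)c2o1`: 5.9 nM
- compound 2 `Cn1cncc1C(O)(c1ccc(C(=O)O)cc1)c1cc2cc([N+](=O)[O-])cc(-c3ccccc3)c2o1`: > 10000 nM, a limit of the assay
- compound 3 `COc1cccc(-c2cc(CN(C)C)cc3cc(C(O)(c4ccc(C#N)cc4)c4cncn4C)oc23)c1`: 142 nM

Among the two true numbers, compound 3 stands highest, and its gap to compound 1 lies beyond the scatter.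

Compound 4 `COc1cccc(-c2cc(C=O)cc3cc(C(O)(c4ccc(C#N)cc4)c4cncn4C)oc23)c1` carries formyl in place of (dimethylamino)methyl on an aromatic carbon. Among the compounds with values here, no measured pair shows this change. Compound 1 also lacks (dimethylamino)methyl and gives 5.9 nM, though it differs elsewhere too. On that slim ground, the expected change in this assay is a modest fall in the number, a 1.8-fold lower number from compound 3 to compound 4 (0.25 log units; within the scatter). For compound 4 the estimated value is 80 nM, with an expected range of 15 nM to 400 nM.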

Compound 4, half-maximal inhibitory concentration: 15.2 nM
Compound 4: middle estimate off by 5.3-fold (0.72 log units), on the high side; measured number inside the range.
By their numbers in this assay, from the lowest: compound 1; then compound 4; then compound 3. At a limit, above all of these: compound 2.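

Formyl in place of (dimethylamino)methyl gives a 9.3-fold lower number from compound 3 to compound 4 (0.97 log units; beyond the scatter) in this assay and is the first change in the series that can be read at a single place. The number at this aromatic carbon, meta to a 3-methoxyphenyl group, therefore responds to the group it carries, and the basic-looking amine side chain is not needed for a low number here. Nothing shown accounts for the size of the step.

On these data alone, whether the step follows the loss of the amine or the arrival of the carbonyl stays open. A hydroxymethyl or a primary aminomethyl group on this carbon would separate the two.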